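Swapping a Fluorophenyl Group for a Chloro-Trifluoromethylphenyl Group

The source may report more compounds than this note shows. Statements on the series, on what has been measured and on what is new or still open speak of the compounds shown alone.

In a functional assay on NCI-H460 cells (Homo sapiens) for antiproliferative activity, read by MTT assay, with a stated time of 72 h (a lower number here means a stronger inhibitor, a higher number a weaker inhibitor), compound 2 `CNC(=O)c1cc(Oc2ccc(NC(=O)c3cc4cccnc4n(-c4ccc(F)cc4)c3=O)cc2)ccn1` gives 210 nM, the lowest of the two numbers available. Compound 1 `CNC(=O)c1cc(Oc2ccc(NC(=O)c3cc4cccnc4n(-c4ccccc4F)c3=O)cc2)ccn1`, which carries 2-fluorophenyl on the same aromatic nitrogen, gives 590 nM; a 2.8-fold lower number from compound 1 to compound 2 (0.45 log units; beyond the scatter). For compound 3 `CNC(=O)c1cc(Oc2ccc(NC(=O)c3cc4cccnc4n(-c4ccc(Cl)cc4)c3=O)cc2)ccn1` the result is "not determined" (no result reported). Compound 4 `CNC(=O)c1cc(Oc2ccc(NC(=O)c3cc4cccnc4n(-c4ccc(C(F)(F)F)cc4Cl)c3=O)cc2)ccn1` differs from compound 2 by 2-chloro-4-(trifluoromethyl)phenyl in place of 4-fluorophenyl on an aromatic nitrogen. Among the compounds with values here, only the step from compound 1 to compound 2 bears on this change, and it shows that altering the fluorophenyl group can shift the number modestly. Within the data shown here, no measured step covers chlorine or trifluoromethyl here, so the direction is uncertain and a wide range is appropriate. Compound 4 is therefore expected to give about 450 nM, likely between 150 nM and 1400 nM. The expected change is a 2.1-fold higher number from compound 2 to compound 4 (0.33 log units; beyond the scatter).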

Compound 4, half-maximal inhibitory concentration: 2110 nM
Beside the measured number, compound 4's estimate is 4.7-fold (0.67 log units) below it; the whole stated range lies below it.
By their numbers in this assay, from the lowest: compound 2; then compound 1; then compound 4.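

In this assay, this position on the aromatic nitrogen proves able to move the number further than the fluorine shift showed, with a 10-fold higher number from compound 2 to compound 4 (1.00 log units; beyond the scatter) and a 3.6-fold higher number from compound 1 to compound 4 (0.55 log units; beyond the scatter). Compound 4 therefore has the highest number of the three compounds with values, and both steps lie beyond the scatter. No measured evidence on why this happens is available here.

Because chlorine and trifluoromethyl enter together, the compounds shown leave open how much each contributes. Also open, on these data alone, is how an amine or a carboxylic acid on this phenyl ring would fare.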